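The compounds below may be only part of what the source reports. "The series", "measured", "known", "first", "only" and "open" are said of these compounds alone.

Working notes on the series. Compound 1 `CCOC(=O)C[n+]1cccc2cc(O)ccc21` lacks the nucleoside part of the others. In a functional assay on U-118-MG cells (Homo sapiens) for cytotoxicity, read by MTT assay, with a stated time of 48 h (on this read-out lower numbers stand for stronger inhibition and higher numbers for weaker inhibition), compound 1 gives > 200000 nM, which is a limit of the assay and not a number (the limit of > 200000 nM in this assay, at which 1 of the 3 values shown sits). Compound 2 `O=C(O[C@H]1C[C@H](n2cc(F)c(=O)[nH]c2=O)O[C@@H]1COP(=O)(O)Oc1ccccc1)c1ccccc1` carries the nucleoside with a phosphate bearing an aromatic ring; in this assay compound 2 gives 970 nM. Compound 3 `CCCCCCCCCc1ccc(OP(=O)(O)OC[C@H]2O[C@@H](n3cc(F)c(=O)[nH]c3=O)C[C@@H]2OC(=O)c2ccccc2)cc1` differs from compound 2 by nonyl in place of hydrogen on an aromatic carbon, and in this assay compound 3 gives 11000 nM; the step is an 11-fold higher number from compound 2 to compound 3 (1.05 log units; beyond the scatter). Of the two numbers available, compound 2 stands lowest, with compound 3 nearest at that step; the remaining value is a limit.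

Compound 4 `C[N+]1(C)CCC(OP(=O)([O-])OC[C@H]2O[C@@H](n3cc(F)c(=O)[nH]c3=O)C[C@@H]2OC(=O)c2ccccc2)CC1` is not yet measured. Against compound 2 the change is a group of 12 heavy atoms (7 carbon, 1 nitrogen, 3 oxygen, 1 phosphorus; one six-membered non-aromatic ring with 1 hetero atom) in place of a group of 10 heavy atoms (6 carbon, 3 oxygen, 1 phosphorus; one six-membered aromatic ring of carbon only), on an oxygen on a saturated carbon. Going by the values given here, the only measured step, from compound 2 to compound 3, also alters the group on this oxygen and gave a large rise, but it is a different alteration and does not fix the present one. A rise in this assay beyond the scatter, though smaller than that of compound 3, is therefore expected for compound 4, a step of a 3.1-fold higher number from compound 2 to compound 4 (0.49 log units; beyond the scatter). Compound 4 is estimated at 3000 nM, within 800 nM to 15000 nM.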

Compound 4, half-maximal inhibitory concentration: 4420 nM
Compound 4: middle estimate off by 1.5-fold (0.17 log units), on the low side; low and high end bracket the measured number.
By their numbers in this assay, from the lowest: compound 2; then compound 4; then compound 3. At a limit, above all of these: compound 1.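

Working notes, continued. The group on an oxygen on a saturated carbon can lose its six-membered aromatic ring of carbon only and still leave a number in this assay rather than a limit: the exchange for the six-membered non-aromatic ring with 1 hetero atom gives a 4.6-fold higher number from compound 2 to compound 4 (0.66 log units; beyond the scatter) as a modest step. With an 11-fold higher number from compound 2 to compound 3 (1.05 log units; beyond the scatter) as the earlier large step, both changes shown at this group raise the number from that of compound 2. No measurement shown bears on why this step occurs.

From the compounds shown here alone, it remains open how a shorter chain in place of nonyl on the aromatic carbon would place between compound 2 and compound 3. Also open, going by these compounds, is whether an amine without the two methyl groups of compound 4, or a carboxylic acid, on this group would stay close to compound 4.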